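Replacing a dicyanophenyl group with a cyanopyridyl group

This account rests on a few compounds, and the source may have more. Where it says the series, first, only, none or still open, it means among the compounds named here.

Compound 2 `C[C@@H]1CN(c2nnc(C(F)(F)F)o2)CCN1c1ncc(OCc2ccc(C#N)cc2C#N)cn1` gives 10 nM in a functional assay on HEK293S cells for agonist activity at Glucose-dependent insulinotropic receptor (Homo sapiens), read by HTRF and cAMP accumulation, with a stated time of 45 min (on this read-out higher numbers stand for an effect only at larger amounts of compound and lower numbers for an effect already at smaller amounts), the higher of the two numbers measured; compound 1 `C[C@@H]1CN(c2nnc(C(F)(F)F)o2)CCN1c1ncc(OCc2ccc(OS(C)(=O)=O)cc2F)cn1` gives 4 nM, and the change a 2.5-fold higher number from compound 1 to compound 2 (0.40 log units; beyond the scatter) was modest. Compound 3 `C[C@@H]1CN(c2nnc(C(F)(F)F)o2)CCN1c1ncc(OCc2ccncc2C#N)cn1` differs from compound 2 only in that (3-cyanopyridin-4-yl in place of 2,4-dicyanophenyl on a saturated chain carbon bound to an oxygen on an aromatic ring). Within the data shown here, the only step that bears on this place is the one from compound 1 to compound 2, and no step shows this exact exchange. Compound 3 is therefore estimated at 15 nM (range 5 nM to 45 nM), a step of a 1.5-fold higher number from compound 2 to compound 3 (0.18 log units; within the scatter) expected to stay near the scatter.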

Compound 3, half-maximal effective concentration: 28 nM
Compound 3: middle estimate off by 1.9-fold (0.27 log units), on the low side, and the stated range covers the measured number.
By their numbers in this assay, from the lowest: compound 1; then compound 2; then compound 3.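

On this saturated chain carbon bound to an oxygen on an aromatic ring, the exchange of 2,4-dicyanophenyl for 3-cyanopyridin-4-yl is not neutral in this assay (a 2.8-fold higher number from compound 2 to compound 3 (0.45 log units; beyond the scatter)). Measured against the 2-fluoro-4-((methylsulfonyl)oxy)phenyl group, 3-cyanopyridin-4-yl gives a larger step (a 7.0-fold higher number from compound 1 to compound 3 (0.85 log units; beyond the scatter)), so this place has now told three aromatic groups apart. The data given here offer no explanation for either step. Open, from the compounds shown here alone, is whether 3-aminopyridin-4-yl or 3-carboxypyridin-4-yl would bring the number back towards that of compound 2.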